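Swapping a benzyl for a fluorophenyl sulfide on the indole

The compounds below may be only part of what the source reports. "The series", "measured", "known", "first", "only" and "open" are said of these compounds alone.

Compound 1 `CN(C)C(=O)n1cc(C(=O)c2ccn3c2CSC3c2cccnc2)c2ccc(OCc3ccccc3)cc21` gives 17 nM in a functional assay (Oryctolagus cuniculus) for antagonist activity at platelet-activating factor receptor (Cavia porcellus); on this read-out lower numbers stand for stronger inhibition and higher numbers for weaker inhibition. Compound 2 `CN(C)C(=O)n1cc(C(=O)c2ccn3c2CSC3c2cccnc2)c2ccc(Cc3ccccc3)cc21` gives 13 nM in this assay. Within the data shown here, the one measured step, a 1.3-fold lower number from compound 1 to compound 2 (0.12 log units; within the scatter), comes from putting benzyl in place of benzyloxy. Compound 2 thus stands at the low end of the two measured numbers, with its gap to compound 1 inside the scatter.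

Compound 3 `CN(C)C(=O)n1cc(C(=O)c2ccn3c2CSC3c2cccnc2)c2ccc(Sc3ccc(F)cc3)cc21` differs from compound 2 by (4-fluorophenyl)sulfanyl in place of benzyl on an aromatic carbon. Among the measured compounds shown here, no measured step involves a sulfur link or a fluorine, so the only step that bears on this change is a 1.3-fold lower number from compound 1 to compound 2 (0.12 log units; within the scatter), which shows that exchanging the link between the shared core and the phenyl ring hardly moved the number. The estimated step of a 1.2-fold higher number from compound 2 to compound 3 (0.09 log units; within the scatter) is therefore expected to be small, in no clear direction. Compound 3 is expected to give about 16 nM in this assay, estimated between 5 nM and 50 nM.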

Compound 3, inhibition constant: 17 nM
For compound 3 the middle estimate is 1.1-fold (0.03 log units) below the measured one, within the range that was stated.
By their numbers in this assay, from the lowest: compounds 2, 1 and 3 (each within the scatter of the next).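

In this assay the (4-fluorophenyl)sulfanyl group reads the same as both earlier groups, with a 1.3-fold higher number from compound 2 to compound 3 (0.12 log units; within the scatter) and no change at the digits printed from compound 1 to compound 3 (within the scatter). The earlier step compared only benzyl and benzyloxy, whereas this result extends the tolerance to a sulfur link and a fluorine on the ring: all three groups on this aromatic carbon give numbers that cannot be told apart. Nothing at hand explains why these groups read alike.

Sulfur and fluorine enter together in compound 3, so their separate contributions cannot be read, and the plain phenylsulfanyl group would be needed to part them. From the compounds shown here alone, how this position responds to an amine, a carboxylic acid or a longer chain in place of these aromatic groups also remains open.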